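Cytotoxicity notes on the cyclic sulfonate ether series

This account rests on a few compounds, and the source may have more. Where it says the series, first, only, none or still open, it means among the compounds named here.

Measured compounds:
compound 1 `CCC1(Cc2ccccc2)OS(=O)(=O)C=C1OCc1ccc(F)cc1` with > 50000 nM
compound 2 `C=CCOC1=CS(=O)(=O)OC1(CC)Cc1ccccc1` with > 200000 nM

In an ADME assay on HEL cells (Homo sapiens) for cytotoxicity, with a stated time of 3 days (a lower number here means that less compound is tolerated, a higher number that more compound is tolerated), compound 1 gives > 50000 nM, which is a limit of the assay and not a number. In this assay compound 2 gives > 200000 nM, again a limit and not a number. The step that the two limits leave unreadable from compound 1 to compound 2 therefore cannot be read, as both ends sit at a limit: one value at the limit of > 200000 nM in this assay, at which 1 of the 2 values shown sits, and one at the limit of > 50000 nM in this assay, at which 1 of the 2 values shown sits.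

Compound 3 `CCC1(Cc2ccccc2)OS(=O)(=O)C=C1OCCc1ccccc1` is not yet measured. It differs from compound 2 by benzyl in place of vinyl on a saturated chain carbon bound to an oxygen on an unsaturated carbon. Within the data shown here, no measured step bears on this change, since the only step, a step that the two limits leave unreadable from compound 1 to compound 2, is unreadable. The expected step of an at least 1.3-fold lower number from compound 2 to compound 3 (0.12 log units; that floor lies within the scatter) in this assay is thus set near zero. Compound 3 is estimated at 150000 nM, with a range from 40000 nM to 400000 nM, most likely reported as a limit again.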

Compound 3, half-maximal cytotoxic concentration: 48000 nM
Estimate against measurement, compound 3: 3.1-fold (0.49 log units) above; low and high end bracket the measured number.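

In this assay, among these compounds, compound 3 gives 48000 nM, the first reading that is a number and not a limit, which shows that tolerance can be read at this position. Allyl to phenethyl, on a saturated chain carbon bound to an oxygen on an unsaturated carbon, gives an at least 4.1-fold lower number from compound 2 to compound 3 (0.61 log units; beyond the scatter), and this size is a floor, since compound 2 stands at a limit: the limit of > 200000 nM in this assay, at which 1 of the 3 values shown sits. Benzyl in place of 4-fluorophenyl gives an at least 1.0-fold lower number from compound 1 to compound 3 (0.01 log units; that floor lies within the scatter), which sets no order between the two compounds, and this floor too rests on a limit, that of compound 1: the limit of > 50000 nM in this assay, at which 1 of the 3 values shown sits.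

From the compounds shown here alone, whether the step follows the entering aromatic ring or the added carbons alone stays open. Also open, going by these compounds, is how an amine, a carboxylic acid or a longer chain at this place would read in this assay.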